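The source may report more compounds than this note shows. Statements on the series, on what has been measured and on what is new or still open speak of the compounds shown alone.

Measured so far in an ADME assay on the whole organism (Rattus norvegicus, strain Sprague-Dawley) for pharmacokinetics, read by LC-MS, with a stated time of 48 h, at a dose of 10 mg/kg by the oral route; on this read-out lower numbers stand for lower exposure and higher numbers for higher exposure at the dose given:

Compound 1 `CC#CCn1c(N2CCC[C@@H](N)C2)cc(=O)n(Cc2ccc(Br)c(C(=O)OC)c2)c1=O` gives 2880 nM
Compound 2 `CC#CCn1c(N2CCC[C@@H](N)C2)cc(=O)n(Cc2ccc(F)c(C(=O)OC)c2)c1=O` gives 1620 nM

Among the compounds with values here, compound 2 stands within the usual scatter of compound 1, the only other compound measured. Compound 3 `CC#CCn1c(N2CCC[C@@H](N)C2)cc(=O)n(Cc2ccc(Cl)c(C(=O)OC)c2)c1=O` has chloro in place of fluoro on an aromatic carbon is the whole change. Within the data shown here, one measured step bears on it, also a halogen exchange on that aromatic carbon: a 1.8-fold lower number from compound 1 to compound 2 (0.25 log units; within the scatter) stays within the scatter. No step beyond the scatter is therefore expected in this assay and no firm direction. The expected size is a 1.3-fold higher number from compound 2 to compound 3 (0.11 log units; within the scatter) and so lies within the scatter. For compound 3 the estimate is 2100 nM with an expected range from 1000 nM to 4400 nM.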

Compound 3, maximal plasma concentration: 7170 nM
The estimate for compound 3 lay 3.4-fold (0.53 log units) below the measured number; the measured number lies above the stated range.
By their numbers in this assay, from the lowest: compounds 2 and 1 (each within the scatter of the next); then compound 3.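

In this assay this position proved more sensitive to the choice of halogen than fluoro and bromo alone had suggested: the exchange gives a 4.4-fold higher number from compound 2 to compound 3 (0.65 log units; beyond the scatter) and also a 2.5-fold higher number from compound 1 to compound 3 (0.40 log units; beyond the scatter). Chloro thus stands apart from both other halogens, and the numbers do not run in order from fluoro through chloro to bromo. No measurement at hand accounts for this. As far as these compounds go, whether a methyl group or a nitrile on this aromatic carbon would match chloro remains open, as does whether chloro's advantage would persist with a carboxylic acid in place of the methoxycarbonyl group.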